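The compounds below may be only part of what the source reports. "The series", "measured", "known", "first", "only" and "open" are said of these compounds alone.

For the measured compounds named here, in a functional assay on CHO-K1 cells for agonist activity at Glucose-dependent insulinotropic receptor (Homo sapiens), read by a luciferase reporter, with a stated time of 5 h (on this read-out lower numbers stand for an effect already at smaller amounts and higher numbers for an effect only at larger amounts of compound), compound 2 `COC(=O)N1CCC(Oc2ncnc3c2CCN3c2ccc(S(C)(=O)=O)cc2F)CC1` gives 316 nM, the highest of the three numbers measured so far. Compound 1 `CC(C)OC(=O)N1CCC(Oc2ncnc3c2CCN3c2ccc(S(C)(=O)=O)cc2)CC1` gives 126 nM, and compound 3 `CCCCOC(=O)N1CCC(Oc2ncnc3c2CCN3c2ccc(S(C)(=O)=O)cc2F)CC1` gives 50.1 nM. Compound 4 `CCS(=O)(=O)N1CCC(Oc2ncnc3c2CCN3c2ccc(S(C)(=O)=O)cc2F)CC1` differs from compound 2 by ethylsulfonyl in place of methoxycarbonyl on an amine nitrogen in a ring. Going by the values given here, the one measured step, a 6.3-fold lower number from compound 2 to compound 3 (0.80 log units; beyond the scatter), lengthened the chain on the methoxycarbonyl rather than replacing that group, so it bears only loosely on the present change; the values of compound 1 and compound 2 concern a different part of the molecule. Among the compounds with values here, with no direct precedent, compound 4 is expected to show a 1.3-fold lower number from compound 2 to compound 4 (0.10 log units; within the scatter), a step not beyond the scatter. The estimate for compound 4 is 250 nM, between 80 nM and 800 nM.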

Compound 4, half-maximal effective concentration: 1580 nM
Estimate against measurement, compound 4: 6.3-fold (0.80 log units) below; measured number above the stated range.
By their numbers in this assay, from the lowest: compound 3; then compound 1; then compound 2; then compound 4.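

Exchanging the group on the amine nitrogen in the ring, rather than lengthening it, matters: ethylsulfonyl in place of methoxycarbonyl gives a 5.0-fold higher number from compound 2 to compound 4 (0.70 log units; beyond the scatter), so more compound is needed for the same effect. The gap to butoxycarbonyl is wider, with a 32-fold higher number from compound 3 to compound 4 (1.50 log units; beyond the scatter), so both groups with a carbonyl outperform ethylsulfonyl here. Nothing measured here explains this loss. Still open, going by these compounds, is whether a longer chain on the sulfonyl, such as butylsulfonyl, would lower the number as butoxycarbonyl did, and how an amide would fare at this nitrogen.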